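This account rests on a few compounds, and the source may have more. Where it says the series, first, only, none or still open, it means among the compounds named here.

In a functional assay on KB cells (Homo sapiens) for cytotoxicity, read by MTT assay, with a stated time of 72 h (a lower number here means a stronger inhibitor, a higher number a weaker inhibitor), three compounds have been measured so far. Compound 1 `O=S(=O)(c1ccc(Br)cc1)c1nc2ccccc2nc1N1CCCC1`, which carries the 4-bromophenyl group, reads > 50000 nM, a limit of the assay and not a number. Within the data shown here, compound 2 `Cc1ccc(S(=O)(=O)c2nc3ccccc3nc2N2CCc3ccccc3C2)cc1` gives 32100 nM, the only true number so far. Compound 3 `COc1ccc(S(=O)(=O)c2nc3ccccc3nc2N2CCc3ccccc3C2)cc1` reads > 50000 nM, which is also a limit. This places compound 3 at the limit of > 50000 nM in this assay, at which 2 of the 3 values shown sit, so its real position is not known.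

Compound 4 `O=S(=O)(c1ccc(Br)cc1)c1nc2ccccc2nc1N1CCc2ccccc2C1` differs from compound 3 by one change, bromo in place of methoxy on an aromatic carbon, para to a large group: bromo in place of methoxy on an aromatic carbon. Among the measured compounds shown here, the one measured step at this place is an at least 1.5-fold higher number from compound 2 to compound 3 (0.19 log units; that floor lies within the scatter), with methoxy in place of methyl. On the evidence of that small step for compound 3, no step beyond the scatter is expected in this assay, and the reading may well remain a limit. The expected change is an at least 1.2-fold lower number from compound 3 to compound 4 (0.09 log units; that floor lies within the scatter). The estimated value for compound 4 is 40000 nM, with an expected range from 18000 nM to 70000 nM.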

Compound 4, half-maximal inhibitory concentration: > 50000 nM
Compound 4 gave a limit, no number; the forecaster's own chance of this, stated with the estimate: 50%; middle value at least 1.2-fold (0.09 log units) from the limit.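

Bromo at this place, para to a large group, gives only a limit of the assay in this assay, just as methoxy does. Among these compounds, the steps from compound 3 and from compound 1 to compound 4 cannot be read, as both ends of each are limits, so the one readable step is an at least 1.5-fold higher number from compound 2 to compound 4 (0.19 log units; that floor lies within the scatter). Compound 2, with its methyl group, therefore remains the only compound here with a true number, and the rest of the set gives no size for any change: the limit of > 50000 nM in this assay, at which 3 of the 4 values shown sit.

Where compound 3 and compound 4 really stand remains unknown, so methoxy and bromo cannot be put in order. Also open, going by these compounds, is whether another group at this place, such as an amine, a carboxylic acid or a longer chain, would give a true number in this assay.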